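The compounds below may be only part of what the source reports. "The series", "measured", "known", "first", "only" and "open" are said of these compounds alone.

Values measured in a functional assay on HeLa cells (Homo sapiens) for cytotoxicity, read by cell counting, with a stated time of 48 h; on this read-out lower numbers stand for an effect already at smaller amounts and higher numbers for an effect only at larger amounts of compound:

Compound 1 `CCCCCCCCCCCCCC(=O)O[C@H]1[C@H](O)[C@H](n2ccc(N)nc2=O)O[C@@H]1CO`: 0.08 ug/mL
Compound 2 `CCCCCCCCCCCCCCCCCCCCCC(=O)OC[C@H]1O[C@@H](n2ccc(N)nc2=O)[C@@H](O)[C@@H]1OC(=O)CCCCCCCCCCCCCCCCCCCCC`: > 10 ug/mL (a limit)
Compound 3 `CCCC(=O)O[C@H]1[C@H](O)[C@H](n2ccc(N)nc2=O)O[C@@H]1CO`: 0.11 ug/mL

Only compound 1 and compound 3 have numbers in this assay, and they cannot be told apart: the data show a 1.4-fold higher number from compound 1 to compound 3 (0.14 log units; within the scatter). Among the measured compounds shown here, compound 1, at 0.08 ug/mL, therefore shares its place on the scale with its one close neighbour. Compound 2 gives only a limit, not a number. For the measured compounds named here, it also differs from compound 1 in more than one place, so it offers no measured step to work from.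

Compound 4 `CCCCCCCC/C=C/CCCCCCCC(=O)O[C@H]1[C@H](O)[C@H](n2ccc(N)nc2=O)O[C@@H]1CO` has not yet been measured. The change is a group of 10 heavy atoms (10 carbon; no ring) in place of a group of 6 heavy atoms (6 carbon; no ring), on a saturated chain carbon, seven bonds along the chain from a carbonyl carbon. Hexyl leaves, and the group that enters carries a double bond outside aromatic rings. Going by the values given here, the one measured step that bears on this change also lies in the chain, and it is large in structural terms, yet it left the number within the scatter: a 1.4-fold higher number from compound 1 to compound 3 (0.14 log units; within the scatter). On that evidence, no shift beyond the scatter is expected in this assay, and no direction can be favoured with confidence. The expected outcome is a 1.5-fold higher number from compound 1 to compound 4 (0.18 log units; within the scatter). Among the compounds with values here, the range is kept wide since no measured step covers a longer chain or a double bond. For compound 4 the estimated value is 0.12 ug/mL, with an expected range from 0.04 ug/mL to 0.4 ug/mL.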

Compound 4, concentration for half-maximal effect: 0.05 ug/mL
The estimate for compound 4 lay 2.4-fold (0.38 log units) above the measured number, and the stated range covers the measured number.
By their numbers in this assay, from the lowest: compounds 4, 1 and 3 (each within the scatter of the next, the first and the last beyond it). At a limit, above all of these: compound 2.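

In this assay, the data show a 1.6-fold lower number from compound 1 to compound 4 (0.20 log units; within the scatter) for the change from hexyl to a group of 10 heavy atoms with a double bond outside aromatic rings, on a saturated chain carbon, seven bonds along the chain from a carbonyl carbon. Among the compounds shown here, the only earlier step in this chain removed carbon atoms, a 1.4-fold higher number from compound 1 to compound 3 (0.14 log units; within the scatter), so compound 4 adds the first reading for a larger group with a double bond at this position, and that reading also stays within the scatter, leaving compounds 1, 3 and 4 with no firm separation along this series of chains. No measurement shown gives a reason for this outcome.

The added length and the double bond arrive in a single step, so their separate contributions cannot be told apart, and a fully saturated chain of the same length would be needed to separate them. Going by these compounds, it also remains open whether a much longer chain, or a chain ending in an amine or a carboxylic acid, would keep the number within the scatter of compound 1.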